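The source may hold more compounds than are shown below. What is called first, only, known or untested is meant among the compounds shown, and "the series" means these compounds.

Among the three compounds measured in a functional assay on WHCO1 cells (Homo sapiens) for antiproliferative activity, read by MTT assay, with a stated time of 48 h (a higher number here means a weaker inhibitor, a lower number a stronger inhibitor), compound 2 `COc1ccc(C[S+]([O-])CC=CSSCc2ccccc2)cc1` stands at the strong end: compound 2 gives 3100 nM, the lowest of the three numbers. Compound 1 `C=CCSSC=CC[S+]([O-])Cc1ccc(OC)cc1` gives 7400 nM, and compound 3 `CCC[S+]([O-])C/C=C/SSC` gives 28000 nM, so compound 2 sits a clear distance from both. For the measured compounds named here, the one step between two measured compounds that differ in a single place, a 2.4-fold lower number from compound 1 to compound 2 (0.38 log units; beyond the scatter), swaps a phenyl for a vinyl group on a saturated chain carbon bound to a sulfur.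

Compound 4 `COc1ccc(CSSC=CC[S+]([O-])Cc2ccc(OC)cc2)cc1` differs from compound 2 by methoxy in place of hydrogen on an aromatic carbon. Going by the values given here, no measured pair shows what adding a methoxy to an aromatic ring does in this assay; the only measured step concerns a different kind of change, so it gives little guidance here. With nothing pointing either way, the expectation is a step within the usual scatter, a 1.0-fold lower number from compound 2 to compound 4 (0.01 log units; within the scatter). Compound 4 is therefore estimated at 3000 nM, with a range from 1500 nM to 6000 nM.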

Compound 4, half-maximal inhibitory concentration: 2100 nM
Estimate against measurement, compound 4: 1.4-fold (0.15 log units) above; low and high end bracket the measured number.
By their numbers in this assay, from the lowest: compounds 4 and 2 (each within the scatter of the next); then compound 1; then compound 3.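

In this assay, adding a methoxy on an aromatic carbon of the ring, para to a large group, gives a 1.5-fold lower number from compound 2 to compound 4 (0.17 log units; within the scatter), so this position accepts the methoxy with no change that can be told from repeat-measurement noise. Putting 4-methoxyphenyl in place of vinyl on the saturated chain carbon bound to a sulfur gives a 3.5-fold lower number from compound 1 to compound 4 (0.55 log units; beyond the scatter), so the earlier gain from phenyl over vinyl also appears with the methoxy-bearing ring. Nothing available gives a reason for either step.

Still open, going by these compounds, is whether any group at this ring position moves the number in this assay, for example a fluorine, a hydroxyl or a dimethylamino group. Also open, on these data alone, is how a longer chain or a pyridine ring would compare with phenyl on that saturated carbon.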